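Swapping the carbonyl substituent on a sulfone-bearing amine series

The source may report more compounds than this note shows. Statements on the series, on what has been measured and on what is new or still open speak of the compounds shown alone.

Measured compounds:
- compound 1 `O=S(=O)(O)CCCNC[C@@H]1CCCc2cc(S(=O)(=O)c3cccc(F)c3)ccc21`: in an assay on isolated protein for displacement of a labelled ligand from 5-hydroxytryptamine receptor 6 (Homo sapiens) (a higher number here means a weaker inhibitor, a lower number a stronger inhibitor), compound 1 gives 1.26 nM
- compound 2 `CN(C)C(=O)NC[C@@H]1CCCc2cc(S(=O)(=O)c3cccc(F)c3)ccc21`: in this assay compound 2 gives 2.51 nM
- compound 3 `COC(=O)NC[C@@H]1CCCc2cc(S(=O)(=O)c3cccc(F)c3)ccc21`: in this assay compound 3 gives 1.59 nM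

All three share one core and differ only in the group carried on the amine nitrogen. Compound 3 sits among the three numbers with none of them set apart from it: the step of a 1.3-fold higher number from compound 1 to compound 3 (0.10 log units; within the scatter) and the step of a 1.6-fold lower number from compound 2 to compound 3 (0.20 log units; within the scatter) both stay within the scatter, as does a 2.0-fold higher number from compound 1 to compound 2 (0.30 log units; within the scatter). Compound 4 `CC(C)(O)C(=O)NC[C@@H]1CCCc2cc(S(=O)(=O)c3cccc(F)c3)ccc21` carries the change (1-hydroxy-1-methylethyl in place of methoxy on a carbonyl carbon). The step that bears on it most directly is a 1.6-fold lower number from compound 2 to compound 3 (0.20 log units; within the scatter), where another exchange on the same carbonyl carbon left the number essentially unchanged; the two other steps on the same nitrogen also stayed within the scatter. For the measured compounds named here, no measured step therefore suggests a shift beyond the scatter for compound 4, and the expected step is a 1.1-fold higher number from compound 3 to compound 4 (0.05 log units; within the scatter). Compound 4 is estimated at 1.8 nM in this assay, with a range from 0.7 nM to 4.5 nM.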

Compound 4, inhibition constant: 2 nM
For compound 4 the middle estimate is 1.1-fold (0.05 log units) below the measured one; the range from low to high includes it.
By their numbers in this assay, from the lowest: compounds 1, 3, 4 and 2 (each within the scatter of the next).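

In this assay, the carbonyl carbon also takes 1-hydroxy-1-methylethyl, a group attached through carbon, with 4 heavy atoms and 1 hydrogen-bond donor against 2 heavy atoms and 0 donors for methoxy (a 1.3-fold higher number from compound 3 to compound 4 (0.10 log units; within the scatter)). The comparisons with the other two compounds also stay within the scatter (a 1.3-fold lower number from compound 2 to compound 4 (0.10 log units; within the scatter); a 1.6-fold higher number from compound 1 to compound 4 (0.20 log units; within the scatter)), so this third kind of carbonyl substituent does not stand apart from the rest of the set. Nothing available gives a reason why these exchanges leave the number within the scatter.

Going by these compounds, whether any group on this nitrogen can move the number beyond the scatter remains open. A carbonyl carrying an aminomethyl group, a carboxylic acid or a longer alkyl chain would test how far this holds.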